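Inverting One Ring Stereocentre in a Glycoside Cytotoxicity Series

A few compounds are considered here, and "the series" means these few. Any claim that something is new, unique, unknown or untested is made for them only; others in the source may bear on it.

Compound 1 `CO[C@@H]1O[C@H](COc2cccc(C(C)C)c2)[C@@H](O)[C@H](O)[C@H]1Oc1ccc(OC2CCCCC2)cc1` is measured in a functional assay on HeLa cells (Homo sapiens) for cytotoxicity, read by MTT assay, with a stated time of 48 h (on this read-out lower numbers stand for an effect already at smaller amounts and higher numbers for an effect only at larger amounts of compound), at 39000 nM, the second highest of the three numbers recorded. Compound 3 `CO[C@@H]1O[C@H](COc2ccccc2C(C)C)[C@@H](O)[C@H](O)[C@H]1Oc1ccc(OC2CCCCC2)cc1` gives 42000 nM, and compound 2 `CO[C@H]1O[C@H](COc2ccc3c(c2)CCCC3)[C@@H](O)[C@H](O)[C@H]1Oc1cccc(C(C)C)c1` gives 33000 nM; both lie within the scatter of compound 1. Among the compounds with values here, the single measured step, a 1.1-fold higher number from compound 1 to compound 3 (0.03 log units; within the scatter), is itself within the scatter. Compound 4 `CO[C@H]1O[C@H](COc2cccc(C(C)C)c2)[C@@H](O)[C@H](O)[C@H]1Oc1ccc(OC2CCCCC2)cc1` differs from compound 1 as follows: the two compounds have the same atoms and bonds and differ only in configuration as drawn: 1 of 5 stereo elements differ; a stereocentre at a saturated ring carbon is drawn R in compound 1 and S in compound 4. Within the data shown here, no measured step isolates such a configuration change, and compound 2, which is drawn with the same configuration at that carbon as compound 4, also carries different aryl groups, so its value merely shows a number within the scatter of compound 1. For compound 4 the expected step is therefore a 1.1-fold lower number from compound 1 to compound 4 (0.02 log units; within the scatter), none beyond the scatter. Compound 4 is estimated at 37000 nM, in the range 18000 nM to 75000 nM.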

Compound 4, half-maximal effective concentration: 28000 nM
Estimate against measurement, compound 4: 1.3-fold (0.12 log units) above; low and high end bracket the measured number.
By their numbers in this assay, from the lowest: compounds 4, 2, 1 and 3 (each within the scatter of the next).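

In this assay, inverting the stereocentre at a saturated ring carbon gives a 1.4-fold lower number from compound 1 to compound 4 (0.14 log units; within the scatter). Within the data shown here, this is the first step that isolates the configuration at this carbon, and the comparison rests on that one feature alone: the fact that compounds 1 and 4 differ only in the configuration as drawn. With these aryl groups, the drawn configuration at this carbon therefore does not move the number beyond the scatter. The compounds shown leave open whether the same inversion would stay within the scatter with an amine or a carboxylic acid on the aryl rings. They also leave open how inversion at the other stereocentres would read.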